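This account rests on a few compounds, and the source may have more. Where it says the series, first, only, none or still open, it means among the compounds named here.

Compound 2 `O=C(/C=C/c1cn(-c2ccccc2)nc1-c1cccnc1)c1cc[nH]c1` is the weaker of the two measured compounds: in a functional assay on MCF7 cells (Homo sapiens) for inhibition, read by sulforhodamine B assay, with a stated time of 72 h (on this read-out higher numbers stand for weaker inhibition and lower numbers for stronger inhibition), compound 2 gives 6900 nM, whereas compound 1 `O=C(/C=C/c1cn(-c2ccccc2)nc1-c1cccnc1)c1ccsc1` gives 500 nM. For the measured compounds named here, the one recorded step between them, a 14-fold higher number from compound 1 to compound 2 (1.14 log units; beyond the scatter), shows that exchanging the ring on the carbonyl carbon can move the read-out strongly. Compound 3 `O=C(/C=C/c1cn(-c2ccccc2)nc1-c1cccnc1)c1c[nH]c2ccccc12` is the next, still unmeasured, member and differs from compound 2 only at that same carbonyl carbon: 1H-indol-3-yl in place of 1H-pyrrol-3-yl on a carbonyl carbon. Going by the values given here, no measured step covers this particular exchange; the step from compound 1 to compound 2 concerns the same position but a different kind of change, so it marks the position as sensitive without fixing a direction. The expected outcome for compound 3 in this assay is therefore a modest move, estimated as a 2.0-fold lower number from compound 2 to compound 3 (0.29 log units; within the scatter), giving 3500 nM with a range from 800 nM to 14000 nM.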

Compound 3, half-maximal inhibitory concentration: 2600 nM
The estimate for compound 3 lay 1.3-fold (0.13 log units) above the measured number; measured number inside the range.
By their numbers in this assay, from the lowest: compound 1; then compound 3; then compound 2.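

In this assay, adding a six-membered aromatic ring of carbon only to 1H-pyrrol-3-yl, which gives 1H-indol-3-yl, produces a 2.7-fold lower number from compound 2 to compound 3 (0.42 log units; beyond the scatter), so the position on the carbonyl carbon accepts this larger group and the number falls rather than rises. The fall does not reach the level of thiophen-3-yl, as the comparison with the sulfur-containing ring shows a 5.2-fold higher number from compound 1 to compound 3 (0.72 log units; beyond the scatter), and so both nitrogen-containing groups, 1H-pyrrol-3-yl and 1H-indol-3-yl, give higher numbers than thiophen-3-yl in these three compounds. Nothing available here accounts for the size or direction of these steps.

Still open, as far as these compounds go, is how a methyl group on the indole nitrogen would compare with the hydrogen there. Also open, from the compounds shown here alone, is whether a non-aromatic group at this position, such as a chain ending in an amine, would be accepted at all.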